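A few compounds are considered here, and "the series" means these few. Any claim that something is new, unique, unknown or untested is made for them only; others in the source may bear on it.

Measured so far:
compound 1 `O=C(/C=C/c1ccc(O)cc1)Nc1nnc(-c2ccccc2)[nH]1` – 1850000 nM
compound 2 `O=C(/C=C/c1ccc(Cl)cc1)Nc1nnc(-c2ccccc2)[nH]1` – 1620000 nM

Both compounds were tested in an ADME assay on Vero cells (Chlorocebus sabaeus) for cytotoxicity, read by MTT assay, with a stated time of 72 h (on this read-out lower numbers stand for higher toxicity in this test and higher numbers for lower toxicity in this test), where compound 1 gives 1850000 nM and compound 2 gives 1620000 nM. Compound 2 carries the lower of the two numbers, though the step of a 1.1-fold lower number from compound 1 to compound 2 (0.06 log units; within the scatter) lies within the scatter. Compound 3 `C=C(C)COc1ccc(/C=C/C(=O)Nc2nnc(-c3ccccc3)[nH]2)cc1` differs from compound 2 by (2-methylprop-2-en-1-yl)oxy in place of chloro on an aromatic carbon. Among the measured compounds shown here, the only measured step, a 1.1-fold lower number from compound 1 to compound 2 (0.06 log units; within the scatter), exchanged one group on that aromatic carbon for another and changed little, so it bears only loosely on a larger group entering there. No step beyond the scatter is expected, a 1.2-fold lower number from compound 2 to compound 3 (0.10 log units; within the scatter). Compound 3 is estimated at 1300000 nM, within a range from 500000 nM to 3000000 nM.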

Compound 3, half-maximal cytotoxic concentration: 1420000 nM
For compound 3 the middle estimate is 1.1-fold (0.04 log units) below the measured one; the range from low to high includes it.
By their numbers in this assay, from the lowest: compounds 3, 2 and 1 (each within the scatter of the next).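

Replacing chloro with (2-methylprop-2-en-1-yl)oxy gives a 1.1-fold lower number from compound 2 to compound 3 (0.06 log units; within the scatter) in this assay and placing 2-methylprop-2-en-1-yl on the oxygen gives a 1.3-fold lower number from compound 1 to compound 3 (0.11 log units; within the scatter) in the same test. This position, para to a large group, has thus taken a group of 5 heavy atoms, including a double bond outside aromatic rings, with no step beyond the scatter. No supporting evidence bears on this result. On these data alone, whether an amine, a carboxylic acid or a longer ether chain at this position would give a step beyond the scatter remains open.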